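The source may report more compounds than this note shows. Statements on the series, on what has been measured and on what is new or still open speak of the compounds shown alone.

In a functional assay on SMMC-7721 cells (Homo sapiens) for inhibition, read by CCK-8 assay, with a stated time of 72 h, tested at 8 uM (a higher number here means more inhibition of growth at the concentration tested, a lower number less inhibition of growth), compound 1 `Cc1ccc(SCc2ccc(C(=O)Nc3ccccc3N)cc2)cc1` gives 82.7%. Within the data shown here, this is the higher of the two numbers available so far, and it lies beyond the usual scatter from compound 2 `COC(=O)c1ccccc1SCc1ccc(C(=O)Nc2ccccc2N)cc1`, which gives 62.5%. Compound 3 `Nc1ccccc1NC(=O)c1ccc(CSc2ccc(Cl)cc2)cc1` keeps the core of compound 1 but carries chloro in place of methyl on an aromatic carbon, para to a large group: chloro in place of methyl on an aromatic carbon. In other words, 4-methylphenyl becomes 4-chlorophenyl. Among the measured compounds shown here, no pair of measured compounds shows this swap, so there is no direct evidence for its effect. With so small a change, no step beyond the scatter is expected in this assay. The estimated step is small, a number 2.7 percentage points lower from compound 1 to compound 3 (within the scatter). Compound 3 is therefore expected to give about 80%, with an estimated range from 65% to 93%.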

Compound 3, percent growth inhibition at one concentration: 16.5%
Beside the measured number, compound 3's estimate is 63.5 percentage points above it; the measured number lies below the stated range.
By their numbers in this assay, from the lowest: compound 3; then compound 2; then compound 1.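

In this assay, replacing methyl with chloro on the aromatic carbon para to a large group gives a number 66.2 percentage points lower from compound 1 to compound 3 (beyond the scatter), so this position is sensitive to which group it carries. The two groups match in what can be counted here, with one heavy atom each, no hydrogen-bond donors or acceptors and no net charge, yet the change from 4-methylphenyl to 4-chlorophenyl still separates the compounds sharply, something compound 1 and compound 2 could not show because they offer no single change to read. No measurement at hand gives a reason for a step of this size.

As far as these compounds go, it remains open whether this drop is specific to chloro or extends to other groups at this position. Compounds carrying fluoro, methoxy or an amine on the same carbon would help to settle that.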